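Propyl to benzyl ester: a step expected within scatter

A few compounds are considered here, and "the series" means these few. Any claim that something is new, unique, unknown or untested is made for them only; others in the source may bear on it.

Compound 2 `CCCOC(=O)C1=C(C)NC(C)=C(C(=O)OC)C1c1csc(-c2ccc(Cl)cc2)n1` carries a propyl ester on a shared core. In an assay on isolated protein for antagonist activity at Voltage-dependent L-type calcium channel subunit alpha-1C (Cavia porcellus), with a stated time of 15 min (a lower number here means a stronger inhibitor, a higher number a weaker inhibitor), compound 2 gives 5920 nM, the highest of three numbers that lie close together: compound 1 `COC(=O)C1=C(C)NC(C)=C(C(=O)OC)C1c1csc(-c2ccc(Cl)cc2)n1` gives 4430 nM and compound 3 `CCCOC(=O)C1=C(C)NC(C)=C(C(=O)OCC)C1c1csc(-c2ccc(Cl)cc2)n1` gives 4090 nM. The step of a 1.3-fold higher number from compound 1 to compound 2 (0.13 log units; within the scatter) and the step of a 1.4-fold lower number from compound 2 to compound 3 (0.16 log units; within the scatter) both alter the same ester chain, and neither moved the number beyond the scatter. Compound 4 `COC(=O)C1=C(C)NC(C)=C(C(=O)OCc2ccccc2)C1c1csc(-c2ccc(Cl)cc2)n1` differs from compound 2 by phenyl in place of ethyl on a saturated chain carbon bound to an oxygen next to a carbonyl group. This change again sits on the ester chain, where the two measured steps were small, so in this assay no step beyond the scatter is expected, a 1.2-fold lower number from compound 2 to compound 4 (0.07 log units; within the scatter). Compound 4 is accordingly estimated at 5000 nM, between 1800 nM and 14000 nM.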

Compound 4, half-maximal inhibitory concentration: 64900 nM
The estimate for compound 4 lay 13-fold (1.11 log units) below the measured number; measured number outside the range, above it.
By their numbers in this assay, from the lowest: compounds 3, 1 and 2 (each within the scatter of the next); then compound 4.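

In this assay the ester chain proved sensitive to this change: phenyl in place of ethyl gave an 11-fold higher number from compound 2 to compound 4 (1.04 log units; beyond the scatter) and phenyl in place of hydrogen gave a 15-fold higher number from compound 1 to compound 4 (1.17 log units; beyond the scatter) on the same saturated chain carbon, both large steps towards a weaker inhibitor. The earlier ethyl and methyl changes there had stayed within the scatter, so this position does not tolerate every change. Nothing available accounts for this result. The compounds shown leave open whether a longer chain such as butyl, without a ring, would stay within the scatter, and what an amine on the ester chain would do.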